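Pyridinyl for Bromophenyl on a Shared Amide Core

A few compounds are considered here, and "the series" means these few. Any claim that something is new, unique, unknown or untested is made for them only; others in the source may bear on it.

Of the compounds shown here, three built on the same core have been measured. Compound 1 `CN(C)CCN(CCN(C)C)c1cccc(C(=O)N2CCc3ccc(OS(N)(=O)=O)cc3C2)c1` gives 17.1% in an assay on HEK293 cells for inhibition of Steryl-sulfatase (Homo sapiens), tested at 1 uM; a lower number here means a weaker effect, a higher number a stronger effect of the compound at the concentration tested. Compound 2 `NS(=O)(=O)Oc1ccc2c(c1)CN(C(=O)c1cccc(N3CCC(Cc4ccccc4)CC3)c1)CC2` gives 41.9% in this assay. Compound 3 `CCN(Cc1cccc(Br)c1)c1ccc(C(=O)N2CCc3ccc(OS(N)(=O)=O)cc3C2)cc1` gives 97.2% in this assay, the highest of the three numbers, and its distance from compound 2 and from compound 1 is in each case beyond the scatter. Compound 4 `CCN(Cc1cccnc1)c1ccc(C(=O)N2CCc3ccc(OS(N)(=O)=O)cc3C2)cc1` has not yet been measured. It differs from compound 3 in one place: pyridin-3-yl in place of 3-bromophenyl on a saturated chain carbon bound to a nitrogen on an aromatic ring. Going by the values given here, no measured pair here differs in a single place, so this change has no measured precedent. Because compound 3 gives 97.2% in this assay, the expected step of a number 12.2 percentage points lower from compound 3 to compound 4 (beyond the scatter) is a modest decrease, possibly within the scatter. Compound 4 is estimated at 85%, with a range from 55% to 98%.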

Compound 4, a percentage reported as inhibition, at one concentration (the size of the read-out at that concentration, not a potency): 85.2%
For compound 4 the middle estimate is 0.2 percentage points below the measured one; measured number inside the range.
By their numbers in this assay, from the lowest: compound 1; then compound 2; then compound 4; then compound 3.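

Going by these compounds alone, this is the only pair that differs in one place: putting pyridin-3-yl in place of 3-bromophenyl gives, in this assay, a number 12 percentage points lower from compound 3 to compound 4 (beyond the scatter). So this place on the chain can lose the bromine and take a ring nitrogen while compound 4 still reaches 85.2%. Nothing measured here gives a reason for the step.

Still open, as far as these compounds go, is which part of the swap carries the step, the lost bromine or the ring nitrogen. A plain phenyl group at this place would separate the two.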